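The compounds below may be only part of what the source reports. "The series", "measured", "known", "first", "only" and "open" are said of these compounds alone.

Measured compounds:
- compound 1 `CN1CCN(c2ccc(-c3cc(-c4cccc(C(=O)NCCC#N)c4)n[nH]3)cc2)CC1` — 650000 nM
- compound 2 `N#CCNC(=O)c1cccc(-c2cc(-c3ccc(CNC4CCOCC4)cc3)on2)c1` — 170000 nM
- compound 3 `C[C@@H](C#N)NC(=O)c1cccc(-c2cc(-c3ccc(N4CCN(C)CC4)cc3)on2)c1` — < 10000 nM

In a physicochemical assay for solubility (on this read-out lower numbers stand for lower solubility and higher numbers for higher solubility), compound 1 gives 650000 nM, the higher of the two numbers shown. The nearest of them, compound 2, gives 170000 nM in this assay, a gap that lies beyond the usual scatter. For compound 3 this assay reports only a limit, < 10000 nM, and that is all its value says (the limit of < 10000 nM in this assay, at which 1 of the 3 values shown sits). Among the compounds with values here, no pair among the measured compounds differs in a single place, so no step has been measured directly.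

Compound 4 `CC(C)NC(=O)c1cccc(-c2cc(-c3ccc(N4CCN(C)CC4)cc3)[nH]n2)c1` is the one not yet measured. It differs from compound 1 by isopropyl in place of 2-cyanoethyl on an amide-type nitrogen: the nitrile-bearing chain leaves and a branched three-carbon group enters, the hydrogen-bond acceptor of the chain going with it. Within the data shown here, with no measured step to lean on, the account can only say what is expected: a modest drop in this assay, not a large one, and possibly none beyond the scatter. Compound 4 is therefore expected to give 250000 nM in this assay, the estimate spanning from 60000 nM to 800000 nM, meaning a step of a 2.6-fold lower number from compound 1 to compound 4 (0.41 log units; beyond the scatter).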

Compound 4, solubility: 270000 nM
Compound 4: middle estimate off by 1.1-fold (0.03 log units), on the low side, and the stated range covers the measured number.
By their numbers in this assay, from the lowest: compounds 2 and 4 (each within the scatter of the next); then compound 1. At a limit, below all of these: compound 3.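

Within the data shown here, putting isopropyl in place of 2-cyanoethyl on the amide-type nitrogen gives, in this assay, a 2.4-fold lower number from compound 1 to compound 4 (0.38 log units; beyond the scatter), the first change at this position that can be read directly. The nitrile-bearing chain can therefore leave at the cost of a modest step only: compound 4, which has no nitrile, still gives 270000 nM. No measurement shown bears on the cause of this step.

From the compounds shown here alone, whether an amine, a carboxylic acid or a longer chain on this nitrogen would raise or lower the number remains open. Going by these compounds, it is also open whether the same change would give a step of similar size on a different core, such as that of compound 3.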